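Cytotoxicity notes: nitro in place of isopropoxy

The source may report more compounds than this note shows. Statements on the series, on what has been measured and on what is new or still open speak of the compounds shown alone.

Compound 1 `CC(C)Oc1cccc(-c2ccc(C(=O)N(Cc3cccc(OCCCCCC(=O)O)c3)C(C)C)cc2)c1` — > 26000 nM, a limit
Compound 2 `COc1cccc(-c2ccc(C(=O)N(Cc3cccc(OCCCCCC(=O)O)c3)C(C)C)cc2)c1` — > 20900 nM, a limit
Compound 3 `CC(C)N(Cc1cccc(OCCCCCC(=O)O)c1)C(=O)c1ccc(-c2cccc(Cl)c2)cc1` — > 21900 nM, a limit

In an ADME assay on HEK293 cells (Homo sapiens) for cytotoxicity, read by CellTiter-Glo and resazurin assay, with a stated time of 72 h (a lower number here means that less compound is needed, a higher number that more compound is needed for the effect), compound 1 gives > 26000 nM, which is a limit of the assay and not a number; it sits at the limit of > 26000 nM in this assay, at which 1 of the 3 values shown sits. Compound 2 sits at the limit of > 20900 nM in this assay, at which 1 of the 3 values shown sits. Compound 3 sits at the limit of > 21900 nM in this assay, at which 1 of the 3 values shown sits. The steps a step that the two limits leave unreadable from compound 1 to compound 2, a step that the two limits leave unreadable from compound 1 to compound 3 and a step that the two limits leave unreadable from compound 2 to compound 3 therefore carry no readable size: methyl in place of isopropyl on the oxygen, or chloro in place of either alkoxy group, leaves every value at a limit.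

Compound 4 `CC(C)N(Cc1cccc(OCCCCCC(=O)O)c1)C(=O)c1ccc(-c2cccc([N+](=O)[O-])c2)cc1` differs from compound 1 as follows: nitro in place of isopropoxy on an aromatic carbon. The change from compound 1 to compound 3 is the nearest comparison, the isopropoxy leaving in favour of another group on the same aromatic carbon, and that step is unreadable. No step beyond the scatter is expected in this assay, and most likely another limit; the expected step is a number no higher from compound 1 to compound 4 (the limit leaves the size open). Compound 4 is estimated at 26000 nM, within 10000 nM to 60000 nM.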

Compound 4, half-maximal effective concentration: > 26000 nM
Compound 4: a limit, no number; the forecaster's own chance of this, stated with the estimate: 85%; the middle value lies on the limit itself.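

Compound 4 also gives a limit and not a number, so its steps to compound 1, compound 2 and compound 3 cannot be read. From the compounds shown here alone, whether any group on this aromatic carbon gives a readable value in this assay remains open, as do the sizes of all these steps.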